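Methyl in Place of Methoxy: Expected Cytotoxicity of Compound 4

The source may hold more compounds than are shown below. What is called first, only, known or untested is meant among the compounds shown, and "the series" means these compounds.

Measured compounds:
compound 1 `COC(=O)c1c(F)cccc1OC(=O)COc1cc(O)c2c(=O)cc(-c3ccccc3)oc2c1`: 319000 nM
compound 2 `COC(=O)c1cc(Cl)ccc1OC(=O)COc1cc(O)c2c(=O)cc(-c3ccccc3)oc2c1`: > 436000 nM, a limit of the assay
compound 3 `COC(=O)c1cccc(OC)c1OC(=O)COc1cc(O)c2c(=O)cc(-c3ccccc3)oc2c1`: 196000 nM

In an ADME assay on cells (T-cell, Mus musculus, strain BALB/c) for cytotoxicity, read by MTT assay, with a stated time of 48 h (on this read-out lower numbers stand for higher toxicity in this test and higher numbers for lower toxicity in this test), compound 3 gives 196000 nM, the lowest of the two numbers shown. Its nearest neighbour is compound 1 at 319000 nM, and the gap between them lies within the scatter. For compound 2 the assay reports only a limit, (the limit of > 436000 nM in this assay, at which 1 of the 3 values shown sits). Among the measured compounds shown here, the single measured step, an at least 1.3-fold higher number from compound 1 to compound 2 (0.13 log units; that floor lies within the scatter), exchanges one substituted ring for another and stays within the scatter.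

Compound 4 `COC(=O)c1cccc(C)c1OC(=O)COc1cc(O)c2c(=O)cc(-c3ccccc3)oc2c1` differs from compound 3 by methyl in place of methoxy on an aromatic carbon. For the measured compounds named here, no measured step exchanges methyl for methoxy, and the one step that is known changes nothing beyond the scatter. Compound 4 is therefore expected to move by a 1.3-fold higher number from compound 3 to compound 4 (0.11 log units; within the scatter), a step not beyond the scatter. In this assay compound 4 is estimated at 250000 nM, with a range from 120000 nM to 500000 nM.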

Compound 4, half-maximal cytotoxic concentration: 299000 nM
Estimate against measurement, compound 4: 1.2-fold (0.08 log units) below; the measured number falls inside the stated range.
By their numbers in this assay, from the lowest: compounds 3, 4 and 1 (each within the scatter of the next). At a limit, above all of these: compound 2.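

In this assay, methyl in place of methoxy on an aromatic carbon gives a 1.5-fold higher number from compound 3 to compound 4 (0.18 log units; within the scatter), so this position, ortho to a large group and meta to a methoxycarbonyl group, now has a measured exchange. The exchange of the fluorine-bearing group for the methyl-bearing group on the oxygen next to a carbonyl group also stays within the scatter, with a 1.1-fold lower number from compound 1 to compound 4 (0.03 log units; within the scatter). The exchange of the chlorine-bearing group for the methyl-bearing group on the same oxygen gives an at least 1.4-fold lower number from compound 2 to compound 4 (0.16 log units; that floor lies within the scatter). Its full size cannot be read because compound 2 is known only as a limit of the assay: the limit of > 436000 nM in this assay, at which 1 of the 4 values shown sits.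

The compounds shown leave open whether an amine, a carboxylic acid or a longer chain such as ethoxy at this position would move the number beyond the scatter. They also leave open what sets the numbers of compound 3 and compound 4.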